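Positional chlorine swap in a Vero cytotoxicity series

The compounds below may be only part of what the source reports. "The series", "measured", "known", "first", "only" and "open" are said of these compounds alone.

Measured so far:
compound 1 `COc1cccc(C2NC(=O)NC(C)=C2C(=O)Nc2ccccc2Cl)c1` — > 100000 nM
compound 2 `CC1=C(C(=O)Oc2ccccc2)C(c2ccccc2)NC(=S)N1` — "non-toxic" (no number reported)
compound 3 `CC1=C(C(=O)Nc2ccccc2Cl)C(c2cnc(CS)n2Nc2ccccc2)NC(=O)N1` — > 100000 nM

In an ADME assay on Vero cells (Chlorocebus sabaeus) for cytotoxicity, read by XTT assay, with a stated time of 72 h (on this read-out lower numbers stand for higher toxicity in this test and higher numbers for lower toxicity in this test), compound 1 gives > 100000 nM, a limit of the assay rather than a number. Compound 2 is recorded as "non-toxic" (no number reported) in this assay, with no number reported. Compound 3 stands at > 100000 nM in this assay, again a limit only. Two of the three entries sit at the limit of > 100000 nM in this assay, at which 2 of the 3 values shown sit.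

Compound 4 `CC1=C(C(=O)Nc2cccc(Cl)c2)C(c2cnc(CS)n2Nc2ccccc2)NC(=O)N1` differs from compound 3 by 3-chlorophenyl in place of 2-chlorophenyl on an amide-type nitrogen — 3-chlorophenyl in place of 2-chlorophenyl on an amide-type nitrogen. Among the compounds with values here, no step between measured compounds exists in this assay, so no measured size of change is available. The step from compound 3 to compound 4 is expected to remain within the scatter, a step that the limit leaves unreadable from compound 3 to compound 4. Compound 4 is estimated at 150000 nM, with a range from 50000 nM to 500000 nM, most probably reported again as a limit.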

Compound 4, half-maximal cytotoxic concentration: 98600 nM
Estimate against measurement, compound 4: 1.5-fold (0.18 log units) above; the range from low to high includes it.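

Within the data shown here, with 3-chlorophenyl on the amide-type nitrogen, compound 4 gives the first actual number in this assay, where the earlier entries gave only limits or a verbal record. The change in chlorine position is read as an at least 1.0-fold lower number from compound 3 to compound 4 (0.00 log units; that floor lies within the scatter), so no effect of this swap on toxicity in this test is established. The comparison remains one-sided: the limit of > 100000 nM in this assay, at which 2 of the 4 values shown sit.

Still open, on these data alone, is whether 4-chlorophenyl on the same nitrogen would give a number or a limit. As far as these compounds go, how an aminophenyl or carboxyphenyl group would read there also remains open.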